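The compounds below may be only part of what the source reports. "The series", "measured", "known", "first", "only" and "open" are said of these compounds alone.

Measured so far in a physicochemical assay for lipophilicity; a higher number here means a more lipophilic compound, a lower number a more polar compound:
compound 1, `Cc1cn(C2CC(N=[N+]=[N-])C(COC(=O)OCCCO)O2)c(=O)[nH]c1=O` — -0.98
compound 2, `Cc1cn(C2CC(N=[N+]=[N-])C(COC(=O)OCCCC(=O)O)O2)c(=O)[nH]c1=O` — -0.55

Compound 2 stands highest of the two numbers; its nearest neighbour is compound 1, and the step of a number 0.43 log units higher from compound 1 to compound 2 (beyond the scatter) lies beyond the scatter.

Compound 3, `Cc1cn(C2CC(N=[N+]=[N-])C(COC(=O)OCCCCO)O2)c(=O)[nH]c1=O`, is not yet measured in this assay. Its difference from compound 2 is hydroxymethyl in place of carboxy on a saturated chain carbon, three bonds along the chain from an oxygen next to a carbonyl group. Put the other way round, compound 2 carries a 3-carboxypropyl group where compound 3 carries a 4-hydroxybutyl one.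

Going by the values given here, the only measured step that bears on this change is the one from compound 1 to compound 2, which runs the opposite way: hydroxy to carboxy gave a number 0.43 log units higher from compound 1 to compound 2 (beyond the scatter). The present change returns to a hydroxy-terminated chain, but compound 3 is not compound 1: compound 1 carries 3-hydroxypropyl, compound 3 4-hydroxybutyl. The step is therefore expected to run downward, and is estimated at a number 0.20 log units lower from compound 2 to compound 3 (within the scatter), somewhat short of a full reversal of the measured step. Compound 3 is expected to come out at about -0.75, within -1.1 to -0.4.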

Compound 3, partition coefficient: -0.68
Estimate against measurement, compound 3: 0.07 log units below; low and high end bracket the measured number.
By their numbers in this assay, from the lowest: compounds 1, 3 and 2 (each within the scatter of the next, the first and the last beyond it).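

Notes on the chain end: in this assay, replacing the carboxy with hydroxymethyl at this place gives a number 0.13 log units lower from compound 2 to compound 3 (within the scatter) and leaves 3-carboxypropyl and 4-hydroxybutyl unresolved, so this change, unlike the earlier step of a number 0.43 log units higher from compound 1 to compound 2 (beyond the scatter), does not separate the two chains. Extending the hydroxy-terminated chain from 3-hydroxypropyl to 4-hydroxybutyl gives a number 0.30 log units higher from compound 1 to compound 3 (within the scatter), which also stays inside the scatter, so compound 3 cannot be told apart from either neighbour, and only the ends of the set, compound 1 and compound 2, are resolved from each other. Going by these compounds alone, the data on hand offer no explanation for any of these steps, including why only the step between compound 1 and compound 2 is resolved.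

The compounds shown leave open whether a hydroxy-terminated chain longer than 4-hydroxybutyl would move clear of the scatter from compound 1, and how 2-carboxyethyl would compare with 3-carboxypropyl on the same core. They also leave open where a chain ending in a primary amine or a methyl ester would fall in this assay relative to the hydroxy and carboxy chain ends.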